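Methoxy for amino: a second instance in the series

The source may report more compounds than this note shows. Statements on the series, on what has been measured and on what is new or still open speak of the compounds shown alone.

Of the compounds shown here, three have been measured in a functional assay on HT-29 cells (Homo sapiens) for inhibition, read by MTT assay, with a stated time of 2 days; a higher number here means a weaker inhibitor, a lower number a stronger inhibitor. Compound 1 `Nc1ccccc1/C=C/c1ccccc1O` gives 36 ug/mL. Compound 2 `Nc1ccccc1/C=C/c1cccc(O)c1` gives 30 ug/mL. Compound 3 `COc1ccccc1/C=C/c1ccccc1O` gives 23 ug/mL. Compound 4 `COc1ccccc1/C=C/c1cccc(O)c1` is not yet measured.

Compound 3 arises from compound 1 by methoxy in place of amino on an aromatic carbon, and in this assay this step gave a 1.6-fold lower number from compound 1 to compound 3 (0.19 log units; within the scatter). The same kind of change takes compound 2 to compound 4: methoxy in place of amino on an aromatic carbon. The two place descriptions read the same word for word, so the change is treated as the same one made on a different core. Compounds 1 and 2 are built from the same atoms joined differently; how the two cores differ is not broken down here. Their values in this assay lie within the scatter of each other, so no order between them is read.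

Going by the values given here, for the step expected from compound 2 to compound 4 in this assay, a 1.6-fold lower number from compound 2 to compound 4 (0.20 log units; within the scatter) is estimated, resting on the single earlier instance because a 1.6-fold lower number from compound 1 to compound 3 (0.19 log units; within the scatter). Compound 4 is therefore expected at about 19 ug/mL, with a plausible range from 10 ug/mL to 36 ug/mL.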

Compound 4, half-maximal inhibitory concentration: 17 ug/mL
Compound 4: the middle estimate sits 1.1-fold (0.05 log units) above what was measured; the range from low to high includes it.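

In this assay, methoxy in place of amino on an aromatic carbon gives a 1.8-fold lower number from compound 2 to compound 4 (0.25 log units; within the scatter), and the two instances of this change agree: the same change on two cores in this assay, a 1.6-fold lower number (0.19 log units; within the scatter) from compound 1 to compound 3 and a 1.8-fold lower number (0.25 log units; within the scatter) from compound 2 to compound 4, 1.1-fold (0.05 log units) apart, within the scatter of two such steps

The change therefore carries from the core of compound 1 to the core of compound 2 without a readable difference in step size, as far as two instances can show. It does not show that the change has a real effect on either core, since each step lies within the scatter, and agreement between two small steps on two closely related cores says little about a more distant core.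

The compounds shown carry only amino or methoxy on this aromatic carbon, so what a longer chain such as ethoxy, or a carboxylic acid, would give there remains open. Also open, on these data alone, is whether the step would hold on a core outside this pair.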